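Quinoline thiosemicarbazones: methoxyphenyl in place of fluorophenyl

A few compounds are considered here, and "the series" means these few. Any claim that something is new, unique, unknown or untested is made for them only; others in the source may bear on it.

Measured so far:
compound 1 `Fc1ccccc1NC(=S)N/N=C/c1ccc2ccccc2n1`: > 100000 nM
compound 2 `NC(=S)N/N=C/c1cc2cccnc2s1`: > 100000 nM

In a functional assay on HL-60 cells (Homo sapiens) for antiproliferative activity, read by sulforhodamine B assay, with a stated time of 72 h (on this read-out higher numbers stand for weaker inhibition and lower numbers for stronger inhibition), compound 1 gives > 100000 nM, which is a limit of the assay rather than a measured number. Compound 2 likewise gives > 100000 nM in this assay, again a limit and not a number. For the measured compounds named here, both values thus sit at the same point, (the limit of > 100000 nM in this assay, at which 2 of the 2 values shown sit), and no compound of the series has yet produced a number inside the measured range. Going by the values given here, no step between two measured compounds can be computed, so the size of any effect of a structural change in this assay is unknown from the data themselves.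

Compound 3 `COc1cccc(NC(=S)N/N=C/c2ccc3ccccc3n2)c1` is the next member to be measured. It differs from compound 1 in one place: 3-methoxyphenyl in place of 2-fluorophenyl on an amide-type nitrogen. The shared core and the thiosemicarbazone linkage are unchanged.

With nothing but limits in hand, the expectation for compound 3 is that it will again be reported at or near the limit, so the step of a number no higher from compound 1 to compound 3 (the limit leaves the size open) is estimated as none beyond the scatter. Compound 3 is accordingly expected to give about 100000 nM in this assay, within a range from 30000 nM to 300000 nM.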

Compound 3, half-maximal inhibitory concentration: 71200 nM
For compound 3 the middle estimate is 1.4-fold (0.15 log units) above the measured one, and the stated range covers the measured number.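

In this assay, for the compounds shown here, compound 3 gives 71200 nM, the first number that is not a limit, so a compound with 3-methoxyphenyl on the amide-type nitrogen can be placed on the scale. Placing 3-methoxyphenyl in place of 2-fluorophenyl at this position gives an at least 1.4-fold lower number from compound 1 to compound 3 (0.14 log units; that floor lies within the scatter); only this floor can be read, and it shows no difference beyond the scatter, while the true size of the step remains undetermined. Compound 3 therefore provides the single numerical anchor for later comparisons at this position, while the other two compounds remain at a limit: the limit of > 100000 nM in this assay, at which 2 of the 3 values shown sit.

The compounds shown leave open whether the methoxy group, the absence of fluorine or neither accounts for the measurable value of compound 3, a question that a plain phenyl on the same nitrogen would help to separate. Also open, going by these compounds, is whether a different group at this position, such as a dimethylamino-substituted phenyl or a longer alkyl chain, would shift the number well beyond the scatter from that of compound 3.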